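Removing the Methoxy Group: From Compound 3 to Compound 4

The source may report more compounds than this note shows. Statements on the series, on what has been measured and on what is new or still open speak of the compounds shown alone.

Three compounds share a bicyclic amine core carrying a pyridine ring, and all were tested in an in vitro assay on SH-SY5Y cells for displacement of a labelled ligand from Neuronal acetylcholine receptor; alpha3/beta4 (Homo sapiens); a higher number here means a weaker inhibitor, a lower number a stronger inhibitor. Compound 1 `Clc1ccncc1C1=CC2CNCC(C1)C2` gives 128 nM in this assay. Compound 2 `FC(F)(F)c1cncc(C2=CC3CNCC(C2)C3)c1` gives 79 nM. Compound 3 `COc1cncc(C2=CC3CNCC(C2)C3)c1` gives 14.3 nM, the lowest of the three numbers; its nearest neighbour is compound 2 and its furthest is compound 1, both steps lying beyond the scatter.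

Compound 4 `C1=C(c2cccnc2)CC2CNCC1C2` has not yet been measured. It differs from compound 3 in one place: hydrogen in place of methoxy on an aromatic carbon. Among the measured compounds shown here, the only measured step touching that position is a 5.5-fold lower number from compound 2 to compound 3 (0.74 log units; beyond the scatter), which shows that changing the group there moves the number by a modest amount. For the measured compounds named here, no measured pair shows what happens when the group is removed entirely, so the direction is uncertain; a modest rise in the number seems the more likely outcome. The estimate is therefore a 2.4-fold higher number from compound 3 to compound 4 (0.39 log units; beyond the scatter), giving an expected value for compound 4 of 35 nM, with a range from 8 nM to 150 nM.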

Compound 4, inhibition constant: 12 nM
Beside the measured number, compound 4's estimate is 2.9-fold (0.46 log units) above it; the measured number falls inside the stated range.
By their numbers in this assay, from the lowest: compounds 4 and 3 (each within the scatter of the next); then compounds 2 and 1 (each within the scatter of the next).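

At this carbon of the six-membered aromatic ring, methoxy can be replaced by hydrogen without a change beyond the scatter in this assay (a 1.2-fold lower number from compound 3 to compound 4 (0.08 log units; within the scatter)), so the low number of compound 3 does not depend on having methoxy there. The earlier gap between trifluoromethyl and methoxy therefore reads differently: compound 4, with no group at all, also stands clearly lower than the trifluoromethyl compound (a 6.6-fold lower number from compound 2 to compound 4 (0.82 log units; beyond the scatter)), and the same holds against the chloro compound (an 11-fold lower number from compound 1 to compound 4 (1.03 log units; beyond the scatter)). No measurement shown here gives a reason for these steps. Still open, going by these compounds, is how an amine, a carboxylic acid or a longer chain such as ethoxy would behave at this carbon. Any of these might match hydrogen and methoxy, or raise the number as trifluoromethyl does.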